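From chlorophenyl to indole on a shared core

The compounds below may be only part of what the source reports. "The series", "measured", "known", "first", "only" and "open" are said of these compounds alone.

Compound 1 `COc1cc(-c2nccn3cc(-c4ccc(F)cc4)nc23)cc(OC)c1OC`: 401 nM
Compound 2 `COc1cc(-c2nccn3cc(-c4ccc(Cl)cc4)nc23)cc(OC)c1OC`: 2090 nM

In a functional assay on MDA-MB-231 cells (Homo sapiens) for inhibition, read by MTT assay, with a stated time of 48 h (a lower number here means a stronger inhibitor, a higher number a weaker inhibitor), compound 2 gives the higher of the two numbers, 2090 nM, which makes it the weaker inhibitor of the pair. Compound 3 `COc1cc(-c2nccn3cc(-c4ccc5[nH]ccc5c4)nc23)cc(OC)c1OC` keeps the shared core but carries 1H-indol-5-yl in place of 4-chlorophenyl on an aromatic carbon. Going by the values given here, only one measured step bears on this change: a 5.2-fold higher number from compound 1 to compound 2 (0.72 log units; beyond the scatter). That step is modest but beyond the scatter, and it only puts chloro in place of fluoro. Among the compounds with values here, no measured compound holds an indole, so this is a loose guide. Compound 2 sits at the top of a very small set, so a step of similar size toward a lower number is expected in this assay. The expected change is a 6.0-fold lower number from compound 2 to compound 3 (0.78 log units; beyond the scatter). For compound 3 the estimated value is 350 nM, with an expected range from 60 nM to 2000 nM.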

Compound 3, half-maximal inhibitory concentration: 74 nM
Estimate against measurement, compound 3: 4.7-fold (0.67 log units) above; measured number inside the range.
By their numbers in this assay, from the lowest: compound 3; then compound 1; then compound 2.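

In this assay, this position accepts a larger group of two fused rings, and the change matters more than the halogen swap did: 1H-indol-5-yl gives a 28-fold lower number from compound 2 to compound 3 (1.45 log units; beyond the scatter) and also a 5.4-fold lower number from compound 1 to compound 3 (0.73 log units; beyond the scatter) here. The earlier pair showed only that the choice of halogen on the phenyl ring shifts the number, whereas compound 3 shows that the phenyl ring itself can be replaced with a clear gain over both halogen compounds. Nothing shown here explains this gain.

Going by these compounds, it remains open whether the gain comes from the second ring or from the indole's hydrogen-bond donor. A naphthyl group, with two rings and no nitrogen, would separate the two, and an indole with a methyl group on its ring nitrogen would test the donor directly.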